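The source may hold more compounds than are shown below. What is called first, only, known or untested is meant among the compounds shown, and "the series" means these compounds.

Compound 1 `C=CCn1nc(Cc2ccc(Cl)cc2)c2ccccc2c1=O` gives 2600 nM in a functional assay on aorta with Alpha-1D adrenergic receptor (Rattus norvegicus) as the target; on this read-out higher numbers stand for an effect only at larger amounts of compound and lower numbers for an effect already at smaller amounts.
Compound 2 `C=CCn1nc(Cc2ccc(SC)cc2)c2ccccc2c1=O` is reported only as an assay limit, > 100000 nM.
Compound 3 `C=CCn1nc(Cc2ccc(OC)cc2)c2ccccc2c1=O` has no result reported in this assay; its entry reads "not determined" (no result reported).

Among the compounds with values here, compound 1 thus holds the only full number in this set. Compound 2 sits at the limit of > 100000 nM in this assay, at which 1 of the 3 values shown sits. Within the data shown here, the single measured step, an at least 38-fold higher number from compound 1 to compound 2 (1.58 log units; beyond the scatter), concerns methylsulfanyl in place of chloro on an aromatic carbon and leaves the allyl chain untouched. Compound 4 `Cn1nc(Cc2ccc(Cl)cc2)c2ccccc2c1=O` differs from compound 1 by hydrogen in place of vinyl on a saturated chain carbon bound to an aromatic nitrogen. Among the measured compounds shown here, no measured step bears on that change, so no shift beyond the scatter is expected in this assay, though the range is kept wide. Compound 4 is therefore estimated at 4000 nM, with a range from 1000 nM to 16000 nM. For compound 4 the expected step is a 1.5-fold higher number from compound 1 to compound 4 (0.19 log units; within the scatter).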

Compound 4, half-maximal effective concentration: 430 nM
The estimate for compound 4 lay 9.3-fold (0.97 log units) above the measured number, outside the stated range (below it).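

The chain on the aromatic nitrogen proves to matter in this assay: allyl to methyl gives a 6.0-fold lower number from compound 1 to compound 4 (0.78 log units; beyond the scatter). The earlier compounds shown here all carried allyl and varied only the aromatic substituent, so they could not show that this position responds to a change, or that the smaller methyl is accepted here with chloro in place. Nothing measured here gives a reason for this shift.

Going by these compounds, whether a propyl chain would behave like allyl or like methyl stays open. So does whether methyl has the same effect alongside methylsulfanyl or methoxy.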